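Trading Two Chlorines for Two Methoxy Groups

This account rests on a few compounds, and the source may have more. Where it says the series, first, only, none or still open, it means among the compounds named here.

For the measured compounds named here, compound 2 `Nc1cc(N)c2nc(-c3ccccc3)c(NCc3ccc(Cl)c(Cl)c3)nc2c1` is the only compound here with a numbered result: in a functional assay on A549 cells (Homo sapiens) for inhibition, read by sulforhodamine B assay, with a stated time of 48 h (a higher number here means a weaker inhibitor of growth, a lower number a stronger inhibitor of growth), compound 2 gives 10700 nM. Compound 1 `CCOC(=O)[C@H](CCC(=O)O)NC(=O)c1ccc(CNc2nc3cc(N)cc(N)c3nc2-c2ccccc2)cc1` returns only < 100000 nM in this assay, which is a limit of the assay and not a number. Compound 3 `COc1ccc(CNc2nc3cc(N)cc(N)c3nc2-c2ccccc2)cc1OC` differs from compound 2 in one place: 3,4-dimethoxyphenyl in place of 3,4-dichlorophenyl on a saturated chain carbon bound to a nitrogen on an aromatic ring. Going by the values given here, no measured step covers a change of this kind, so any direction is expectation alone; a modest weakening beyond the usual scatter is expected, with a 2.1-fold higher number from compound 2 to compound 3 (0.31 log units; beyond the scatter) as the estimated size. Compound 3 is expected to give about 22000 nM in this assay, in a range from 6000 nM to 80000 nM.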

Compound 3, concentration for 50% growth inhibition: 20900 nM
The estimate for compound 3 lay 1.1-fold (0.02 log units) above the measured number, and the stated range covers the measured number.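

Placing 3,4-dimethoxyphenyl in place of 3,4-dichlorophenyl on a saturated chain carbon bound to a nitrogen on an aromatic ring gives a 2.0-fold higher number from compound 2 to compound 3 (0.29 log units; within the scatter) in this assay. For the compounds shown here, this is the first measured step at this position, and it shows that these two groups cannot be told apart in this read-out. Nothing shown here accounts for that result.

Still open, from the compounds shown here alone, is whether an amine on this ring, or a longer chain linking the ring to the nitrogen, would separate from these two compounds.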